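This account rests on a few compounds, and the source may have more. Where it says the series, first, only, none or still open, it means among the compounds named here.

Measured so far in a functional assay on P388 cells (Mus musculus) for cytotoxicity; on this read-out higher numbers stand for weaker inhibition and lower numbers for stronger inhibition:
Compound 1 `COc1ccc(C[C@H]2C(=O)N[C@@H](C)C(=O)N(C)[C@H]3Cc4ccc(cc4)Oc4cc(ccc4OC)C[C@@H](C(=O)N[C@H](C)C(=O)N[C@@H](CCC(=O)O)C(=O)N2C)N(C)C3=O)cc1` gives 219 nM.
Compound 2 `COc1ccc(C[C@H]2C(=O)N[C@@H](C)C(=O)N(C)[C@H]3Cc4ccc(cc4)Oc4cc(ccc4OC)C[C@@H](C(=O)N[C@H](C)C(=O)N[C@@H](CSC(C)=O)C(=O)N2C)N(C)C3=O)cc1` gives 9.77 nM.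
Compound 3 `COc1ccc(C[C@H]2C(=O)N[C@@H](C)C(=O)N(C)[C@H]3Cc4ccc(cc4)Oc4cc(ccc4OC)C[C@@H](C(=O)N[C@H](C)C(=O)NC4(SCCS4)C(=O)N2C)N(C)C3=O)cc1` gives 631 nM.

Compound 2 holds the lowest number of the three, that is the strongest inhibition; compound 3 is furthest away, and compound 1 is nearer but still clearly apart. Compound 4 `COc1ccc(C[C@H]2C(=O)N[C@@H](C)C(=O)N(C)[C@H]3Cc4ccc(cc4)Oc4cc(ccc4OC)C[C@@H](C(=O)N[C@H](C)C(=O)N[C@@H](CCCCO)C(=O)N2C)N(C)C3=O)cc1` differs from compound 2 in one place: 3-hydroxypropyl in place of acetylsulfanyl on a saturated chain carbon bound to a saturated ring carbon. Going by the values given here, the one step that bears on this is a 22-fold lower number from compound 1 to compound 2 (1.35 log units; beyond the scatter), where acetylsulfanyl entering in place of carboxymethyl brought the number far down. Compound 4 removes that acetylsulfanyl again, so a rise back toward the region of compound 1 and compound 3 is expected, though 3-hydroxypropyl matches neither of those groups. For compound 4 the estimate is 100 nM, between 25 nM and 400 nM, a step of a 10-fold higher number from compound 2 to compound 4 (1.01 log units; beyond the scatter).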

Compound 4, half-maximal inhibitory concentration: 219 nM
The estimate for compound 4 lay 2.2-fold (0.34 log units) below the measured number; measured number inside the range.
By their numbers in this assay, from the lowest: compound 2; then compounds 1 and 4 (each within the scatter of the next); then compound 3.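

In this assay, 3-hydroxypropyl in place of acetylsulfanyl gives a 22-fold higher number from compound 2 to compound 4 (1.35 log units; beyond the scatter), so the low number of compound 2 does not carry over to this other group, although both groups have 4 heavy atoms. Exchanging carboxy for 2-hydroxyethyl gives no change at the digits printed from compound 1 to compound 4 (within the scatter), so among compounds 1, 2 and 4 only the acetylsulfanyl compound stands apart. Nothing shown gives a cause for either step.

From the compounds shown here alone, it remains open whether the low number of compound 2 depends on the sulfur, the carbonyl or both. A free thiol, an acetoxy group or an amine on this chain could separate these possibilities.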